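Swapping Hydroxymethyl for Isopropyl on the Amino Ester Arm

The source may hold more compounds than are shown below. What is called first, only, known or untested is meant among the compounds shown, and "the series" means these compounds.

Compound 1, `COC(=O)C[C@@H](NC(=O)Cn1cc(C2=C(c3c[nH]c4ccccc34)C(=O)N(C)C2=O)c2ccccc21)C(=O)OC`, in a functional assay on A549 cells (Homo sapiens) for cytotoxicity, read by MTT assay, with a stated time of 24 h (a higher number here means a weaker inhibitor, a lower number a stronger inhibitor), gives 74200 nM.
Compound 2, `COC(=O)[C@@H](CO)NC(=O)Cn1cc(C2=C(c3c[nH]c4ccccc34)C(=O)N(C)C2=O)c2ccccc21`, in this assay gives 37900 nM.

Going by the values given here, compound 2 holds the lowest of the two numbers, its only neighbour being compound 1, a difference of a 2.0-fold lower number from compound 1 to compound 2 (0.29 log units; within the scatter). Compound 3, `COC(=O)[C@H](NC(=O)Cn1cc(C2=C(c3c[nH]c4ccccc34)C(=O)N(C)C2=O)c2ccccc21)C(C)C`, differs from compound 2 by isopropyl in place of hydroxymethyl on a saturated chain carbon bound to an amide-type nitrogen and a carbonyl carbon. Among the compounds with values here, the single step bearing on this region of the chain, a 2.0-fold lower number from compound 1 to compound 2 (0.29 log units; within the scatter), stayed within the scatter, so no change beyond the scatter is expected in this assay. Compound 3 is therefore estimated at 40000 nM, within 15000 nM to 110000 nM, a step of a 1.1-fold higher number from compound 2 to compound 3 (0.02 log units; within the scatter).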

Compound 3, half-maximal inhibitory concentration: 30600 nM
Beside the measured number, compound 3's estimate is 1.3-fold (0.12 log units) above it; the measured number falls inside the stated range.
By their numbers in this assay, from the lowest: compounds 3, 2 and 1 (each within the scatter of the next, the first and the last beyond it).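

In this assay, isopropyl in place of hydroxymethyl on this saturated chain carbon leaves the number within the scatter (a 1.2-fold lower number from compound 2 to compound 3 (0.09 log units; within the scatter)), even though the hydrogen-bond donor and acceptor of hydroxymethyl are gone. Isopropyl in place of (methoxycarbonyl)methyl at the same carbon gives the first step here beyond the scatter, though a modest one (a 2.4-fold lower number from compound 1 to compound 3 (0.38 log units; beyond the scatter)). No measurement on hand accounts for either step.

The compounds shown leave open whether an amine, a carboxylic acid or a longer chain on this carbon would shift the number further.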